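Amino Group Removed from a Carbonyl Carbon: Compound 4

A few compounds are considered here, and "the series" means these few. Any claim that something is new, unique, unknown or untested is made for them only; others in the source may bear on it.

Compound 3 `O=C(Nc1ccc(-n2cc(-c3ccncc3)c(-c3ccc(Cl)c(O)c3)n2)cc1)Nc1ccc(Cl)c(C(F)(F)F)c1` was tested in a functional assay on UACC-62 cells (Homo sapiens) for antiproliferative activity, read by sulforhodamine B assay, with a stated time of 48 h (a higher number here means a weaker inhibitor, a lower number a stronger inhibitor), where compound 3 gives 1700 nM. That is the lowest of the three numbers measured, yet all three lie within the scatter of one another: compound 1 `COc1cc(-c2nn(-c3ccc(NC(=O)Nc4ccc(Cl)c(C(F)(F)F)c4)cc3)cc2-c2ccncc2)ccc1Cl` gives 1770 nM and compound 2 `COc1cc(-c2nn(-c3ccc(NC(=O)c4ccc(Cl)c(C(F)(F)F)c4)cc3)cc2-c2ccncc2)ccc1Cl` gives 2180 nM. Compound 4 `O=C(Nc1ccc(-n2cc(-c3ccncc3)c(-c3ccc(Cl)c(O)c3)n2)cc1)c1ccc(Cl)c(C(F)(F)F)c1` differs from compound 3 in one place: 4-chloro-3-(trifluoromethyl)phenyl in place of (4-chloro-3-(trifluoromethyl)phenyl)amino on a carbonyl carbon. The same change appears in one measured pair, where it gave a 1.2-fold higher number from compound 1 to compound 2 (0.09 log units; within the scatter). The other measured step, a 1.0-fold lower number from compound 1 to compound 3 (0.02 log units; within the scatter), concerns a different change and bears only indirectly. On that basis no step beyond the scatter is expected for compound 4, and its estimated step is a 1.2-fold higher number from compound 3 to compound 4 (0.07 log units; within the scatter). Compound 4 is therefore expected to give about 2000 nM, within a range from 1000 nM to 4000 nM.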

Compound 4, half-maximal inhibitory concentration: 2030 nM
The estimate for compound 4 lay 1.0-fold (0.01 log units) below the measured number; the measured number falls inside the stated range.
By their numbers in this assay, from the lowest: compounds 3, 1, 4 and 2 (each within the scatter of the next).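

In this assay, the loss of the amino group from the carbonyl carbon now gives a 1.2-fold higher number from compound 3 to compound 4 (0.08 log units; within the scatter), so this change stands on a second core: the same change on two cores in this assay, a 1.2-fold higher number (0.09 log units; within the scatter) from compound 1 to compound 2 and a 1.2-fold higher number (0.08 log units; within the scatter) from compound 3 to compound 4, 1.0-fold (0.01 log units) apart, within the scatter of two such steps. Hydrogen in place of methyl on the oxygen likewise gives a 1.1-fold lower number from compound 2 to compound 4 (0.03 log units; within the scatter), and this change also repeats: the same change on two cores in this assay, a 1.0-fold lower number (0.02 log units; within the scatter) from compound 1 to compound 3 and a 1.1-fold lower number (0.03 log units; within the scatter) from compound 2 to compound 4, 1.0-fold (0.01 log units) apart, within the scatter of two such steps. Across these four compounds, neither change moves the number beyond the scatter, whichever form the other place takes.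

On these data alone, what remains open is whether any group on this carbonyl carbon would produce a step beyond the scatter. An amine or a carboxylic acid in place of the 4-chloro-3-(trifluoromethyl)phenyl could test this.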